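Adding a Third Methoxy Group to Compound 3

A few compounds are considered here, and "the series" means these few. Any claim that something is new, unique, unknown or untested is made for them only; others in the source may bear on it.

Compound 1 `Cc1cc(O)c(C(C)C)cc1-c1cc(-c2ccccc2)c(C#N)c(=O)[nH]1` gives 22% in a functional assay for inhibition, tested at 20 ug/mL; a higher number here means a stronger effect of the compound at the concentration tested, a lower number a weaker effect.
Compound 2 `COc1cccc(-c2cc(-c3cc(C(C)C)c(O)cc3C)[nH]c(=O)c2C#N)c1` gives 22% in this assay.
Compound 3 `COc1ccc(-c2cc(-c3cc(C(C)C)c(O)cc3C)[nH]c(=O)c2C#N)c(OC)c1` gives 27% in this assay.

Compound 4 `COc1cc(OC)c(-c2cc(-c3cc(C(C)C)c(O)cc3C)[nH]c(=O)c2C#N)c(OC)c1` has not yet been measured. It differs from compound 3 in one place: methoxy in place of hydrogen on an aromatic carbon. The same kind of change has already been measured once, from compound 1 to compound 2: methoxy in place of hydrogen on an aromatic carbon. That step came out as no change at the digits printed from compound 1 to compound 2 (within the scatter). The two cores are not identical; compound 3 differs from compound 1 in that (2,4-dimethoxyphenyl in place of phenyl on an aromatic carbon). The surroundings of the change also differ: in compound 1 the entering methoxy sits meta to a large group, whereas in compound 3 it sits ortho to a large group and meta to two methoxy groups, so the two changes are of the same kind rather than the same. Because no change at the digits printed from compound 1 to compound 2 (within the scatter) stayed within the scatter, a step of about no change at the digits printed from compound 3 to compound 4 (within the scatter) is expected here as well. Compound 4 is therefore estimated at 27%, between 12% and 42%.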

Compound 4, a percentage reported as inhibition, at one concentration (the size of the read-out at that concentration, not a potency): 32%
The estimate for compound 4 lay 5 percentage points below the measured number; measured number inside the range.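

Putting methoxy in place of hydrogen on an aromatic carbon gives a number 5 percentage points higher from compound 3 to compound 4 (within the scatter) in this assay. Set beside the earlier step, the change reads alike on both cores: the same change on two cores in this assay, no change at the digits printed (within the scatter) from compound 1 to compound 2 and a number 5 percentage points higher (within the scatter) from compound 3 to compound 4, 5 percentage points apart, within the scatter of two such steps. This shows only that, in these two examples, the change leaves the read-out within the usual scatter on either core; it does not show that methoxy is without effect, and two examples at one concentration make no rule for other cores or for other places on the ring.

The compounds shown leave open whether a different group on these aromatic rings, such as an amine, a carboxylic acid or a longer alkoxy chain, would move the number beyond the scatter.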